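A Hydroxy Group Enters the Amine Side Chain

The compounds below may be only part of what the source reports. "The series", "measured", "known", "first", "only" and "open" are said of these compounds alone.

Three compounds have been measured in a functional assay on MCF7 cells (Homo sapiens) for antiproliferative activity; on this read-out lower numbers stand for stronger inhibition and higher numbers for weaker inhibition:

Compound 1, `CC(=O)Oc1ccc(C(=O)Nc2cc3ccc(OCCC4CCCCN4)c(C)c3oc2=O)cc1CC=C(C)C`, gives 710 nM.
Compound 2, `CC(=O)Oc1ccc(C(=O)Nc2cc3ccc(OCC4CCCNC4)c(C)c3oc2=O)cc1CC=C(C)C`, gives 820 nM.
Compound 3, `CCCNCCCOc1ccc2cc(NC(=O)c3ccc(O)c(CC=C(C)C)c3)c(=O)oc2c1C`, gives 980 nM.

Compound 3 holds the highest of the three numbers, yet its distances to compound 2 and to compound 1 both lie within the usual scatter, so the three compounds cannot be told apart on this read-out.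

Compound 4, `CC(C)=CCc1cc(C(=O)Nc2cc3ccc(OCCCNCCO)c(C)c3oc2=O)ccc1O`, differs from compound 3 in one place: hydroxy in place of methyl on a saturated chain carbon, two bonds along the chain from an amine nitrogen. Going by the values given here, no measured step exchanges methyl for hydroxy. Among the compounds with values here, the one measured step that touches the amine-bearing side chain, a 1.2-fold higher number from compound 1 to compound 2 (0.06 log units; within the scatter), reshapes that chain at a different point and stays within the scatter, which is the only guidance available. On this basis the step is expected to be small, a 1.0-fold higher number from compound 3 to compound 4 (0.01 log units; within the scatter), with no direction beyond the scatter. Compound 4 is therefore estimated at 1000 nM in this assay, within a range of 450 nM to 2200 nM.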

Compound 4, half-maximal inhibitory concentration: 1560 nM
The estimate for compound 4 lay 1.6-fold (0.19 log units) below the measured number; measured number inside the range.
By their numbers in this assay, from the lowest: compounds 1, 2, 3 and 4 (each within the scatter of the next, the first and the last beyond it).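

Going by these compounds alone, the first measured exchange of methyl for hydroxy at this place gives a 1.6-fold higher number from compound 3 to compound 4 (0.20 log units; within the scatter) in this assay and so stays within the scatter. Within the data shown here, for this one pair, propylamino can therefore give way to (2-hydroxyethyl)amino, bringing in the hydrogen-bond donor and acceptor counted for hydroxy, with no step that this read-out can separate from repeated measurement. Nothing available bears on the reason for this result.

From the compounds shown here alone, whether a methoxy group, an amine or a carboxylic acid at the same place would give a step beyond the scatter remains open. So does whether a longer chain ending in hydroxy would behave as (2-hydroxyethyl)amino does here, and whether the same exchange would give a similar step on another amine side chain.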